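The source may hold more compounds than are shown below. What is called first, only, known or untested is meant among the compounds shown, and "the series" means these compounds.

Of the compounds shown here, three have numbers so far in an ADME assay on Vero cells (Chlorocebus sabaeus) for inhibition, read by sulforhodamine B assay, with a stated time of 48 h; a lower number here means a stronger inhibitor of growth, a higher number a weaker inhibitor of growth. Compound 1 (`COc1cc(C(=O)NNC(=O)c2ccc3[nH]c(-c4ccc([N+](=O)[O-])s4)nc3c2)cc(OC)c1OC`) gives 31.3 ug/mL, compound 2 (`COc1cccc(C(=O)NNC(=O)c2ccc3[nH]c(-c4ccc([N+](=O)[O-])o4)nc3c2)c1`) gives 31.3 ug/mL, and compound 3 (`O=C(NNC(=O)c1cc2ccccc2cc1O)c1ccc2[nH]c(-c3ccc([N+](=O)[O-])s3)nc2c1`) gives 31.3 ug/mL. Compound 3 therefore stands level with compound 1 and compound 2 at the digits reported. Among the compounds with values here, no step between measured compounds is available to scale from.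

The next entry is compound 4 (`COc1cccc(C(=O)NNC(=O)c2ccc3[nH]c(-c4ccc([N+](=O)[O-])s4)nc3c2)c1`). It has 3-methoxyphenyl in place of 3-hydroxynaphthalen-2-yl on a carbonyl carbon, a change that counts as follows: 3-methoxyphenyl in place of 3-hydroxynaphthalen-2-yl on a carbonyl carbon.

The expectation in this assay is no shift beyond the scatter, in either direction. The basis is thin and rests on two observations. Compound 2 also carries 3-methoxyphenyl on a carbonyl carbon and gives 31.3 ug/mL. The three measured compounds also show no spread at all, despite their different groups in this place. The estimated step is no change at the digits printed from compound 3 to compound 4 (within the scatter), expected to stay within the scatter. For compound 4 the expected value is 31.3 ug/mL, with an estimated range from 15 ug/mL to 65 ug/mL.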

Compound 4, concentration for 50% growth inhibition: > 250 ug/mL
Compound 4: a limit, no number; the forecaster's own chance of this, stated with the estimate: 15%; at least 7.9-fold (0.90 log units) between middle value and limit.
By their numbers in this assay, from the lowest: compounds 1, 2 and 3 (each within the scatter of the next). At a limit, above all of these: compound 4.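

In this assay compound 4 stands at a limit and not at a number: the limit of > 250 ug/mL in this assay, at which 1 of the 4 values shown sits. The level shared by compounds 1, 2 and 3 had given no sign that the readout responds to either place, but 3-methoxyphenyl in place of 3-hydroxynaphthalen-2-yl on a carbonyl carbon gives an at least 7.9-fold higher number from compound 3 to compound 4 (0.90 log units; beyond the scatter), and 5-nitrothiophen-2-yl in place of 5-nitrofuran-2-yl on an aromatic carbon gives an at least 7.9-fold higher number from compound 2 to compound 4 (0.90 log units; beyond the scatter). Neither group sets the result alone, since compound 2 also carries 3-methoxyphenyl and compound 3 also carries 5-nitrothiophen-2-yl, so among these compounds the high reading appears only with the two groups together in compound 4.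

The true size of both steps stays open, as does any cause for them, and the limit gives only a lower bound on each. Going by these compounds, it is also open whether an amine or a carboxylic acid in place of the methoxy group of compound 4 would keep this reading or return it to the level of compound 3.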